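A second chlorine added to a non-toxic scaffold

The compounds below may be only part of what the source reports. "The series", "measured", "known", "first", "only" and "open" are said of these compounds alone.

Compound 2, with the structure `Nc1nc(-c2ccccc2)nn1-c1ncnc2cc(Cl)ccc12`, was tested in an ADME assay on BJ cells (Homo sapiens) for cytotoxicity, with a stated time of 72 h; on this read-out higher numbers stand for an effect only at larger amounts of compound and lower numbers for an effect already at smaller amounts. In this assay compound 2 gave > 50000 nM, which is a limit of the assay rather than a measured number. The related compound 1, with the structure `Nc1nc(-c2ccccc2)nn1-c1ncnc2ccccc12`, was tested in the same assay; compound 1 gave > 50000 nM, again a limit. The step that the two limits leave unreadable from compound 1 to compound 2 therefore cannot be read, as both of its ends sit at the limit; this is summarised by the limit of > 50000 nM in this assay, at which 2 of the 2 values shown sit.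

Compound 3, with the structure `Nc1nc(-c2ccc(Cl)cc2)nn1-c1ncnc2cc(Cl)ccc12`, has not yet been measured. It differs from compound 2 by chloro in place of hydrogen on an aromatic carbon, that is, the phenyl of compound 2 becomes 4-chlorophenyl in compound 3. Among the measured compounds shown here, the only measured step, the one from compound 1 to compound 2, is of the same kind and was unreadable, so it neither argues for a change beyond the scatter nor against one. Compound 3 is therefore expected to stay near the limit, with an estimated step of a number no higher from compound 2 to compound 3 (the limit leaves the size open). The estimate for compound 3 in this assay is 50000 nM, within 15000 nM to 150000 nM.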

Compound 3, half-maximal effective concentration: > 47000 nM
Compound 3 gave a limit, no number; the forecaster's own chance of this, stated with the estimate: 75%; the middle value is on the limit's open side.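

In this assay compound 3 gives > 47000 nM, which is a limit and not a number. Compound 2 also sits at a limit, so the step between compound 2 and compound 3 cannot be read. The compounds shown leave open where any of the three would show a measurable effect, and whether either chlorine changes it.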